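A Sulfur Swap in the Propoxy Chain

A few compounds are considered here, and "the series" means these few. Any claim that something is new, unique, unknown or untested is made for them only; others in the source may bear on it.

In a functional assay on a cell-free system (plasma, Homo sapiens) for inhibition, with Plasma (Rattus norvegicus) as the target (on this read-out lower numbers stand for stronger inhibition and higher numbers for weaker inhibition), compound 1 `CCCOc1ccc2c(N3CCNCC3)cc(=O)oc2c1C` gives 2950 nM as the lower of two numbers, and compound 2 `O=c1cc(N2CCNCC2)c2ccc(OCc3cccnc3)cc2o1` gives 21300 nM with a gap beyond the scatter. Compound 3 `CSCOc1ccc2c(N3CCNCC3)cc(=O)oc2c1C` differs from compound 1 by one change (methylsulfanyl in place of ethyl on a saturated chain carbon bound to an oxygen on an aromatic ring) with methylsulfanyl in place of ethyl on a saturated chain carbon bound to an oxygen on an aromatic ring. Within the data shown here, with compound 1 at 2950 nM as the anchor and no measured pair showing such a change, no step beyond the scatter is expected in this assay here. An estimated 1.0-fold higher number from compound 1 to compound 3 (0.01 log units; within the scatter) is expected. For compound 3 the estimate is 3000 nM with a range from 1200 nM to 7500 nM expected.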

Compound 3, half-maximal inhibitory concentration: 900 nM
The estimate for compound 3 lay 3.3-fold (0.52 log units) above the measured number; the measured number lies below the stated range.
By their numbers in this assay, from the lowest: compound 3; then compound 1; then compound 2.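

In this assay, methylsulfanyl in place of ethyl on a saturated chain carbon bound to an oxygen on an aromatic ring gives a 3.3-fold lower number from compound 1 to compound 3 (0.52 log units; beyond the scatter) and so shows that this chain position responds to the swap, even though the heavy-atom count stays the same and sulfur enters for one carbon. No measurement given here bears on the reason for this step. The compounds shown leave open whether a methoxymethyl chain, with oxygen where the sulfur stands, or a longer chain such as butyl would move the number in the same direction.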